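Amide side-chain exchange on the shared core

The source may report more compounds than this note shows. Statements on the series, on what has been measured and on what is new or still open speak of the compounds shown alone.

Measured so far:
compound 1, `Cc1nn(CC(=O)N2CCN(c3sc(C(F)(F)F)nc3-c3nc4ccccc4[nH]3)C[C@H]2C)cc1CN(C)C` — 2.7 nM
compound 2, `Cc1nc(C)n(CC(=O)N2CCN(c3sc(C(F)(F)F)nc3-c3nc4c(C(F)(F)F)cccc4[nH]3)C[C@H]2C)n1` — 6 nM

Both were read in a functional assay on CHO-K1 cells for antagonist activity at C-X-C chemokine receptor type 3 (Homo sapiens), read by FLIPR, with a stated time of 10 min, in the presence of a further agent that is not named here; a lower number here means a stronger inhibitor, a higher number a weaker inhibitor. Compound 1 gives 2.7 nM, the lowest of the two numbers; compound 2 gives 6 nM, a gap beyond the usual scatter, and since the two differ in more than one place only their two values are noted. Compound 3, `C[C@@H]1CN(c2sc(C(F)(F)F)nc2-c2nc3ccccc3[nH]2)CCN1C(=O)Cn1cc(C2CCN(C)CC2)cn1`, is yet to be measured in this assay. Relative to compound 1 it carries 4-(1-methylpiperidin-4-yl)-1H-pyrazol-1-yl in place of 4-((dimethylamino)methyl)-3-methyl-1H-pyrazol-1-yl on a saturated chain carbon bound to a carbonyl carbon; the shared core and the amide linkage are unchanged. Among the compounds with values here, nothing measured so far isolates this exchange. Within the data shown here, with no comparable step in hand, the expectation for compound 3 is a step of a 1.5-fold higher number from compound 1 to compound 3 (0.17 log units; within the scatter) that stays within the scatter, or at most a small weakening. Compound 3 is accordingly estimated at 4 nM, with a range of 1.5 nM to 12 nM.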

Compound 3, half-maximal inhibitory concentration: 15 nM
Estimate against measurement, compound 3: 3.8-fold (0.57 log units) below; measured number outside the range, above it.
By their numbers in this assay, from the lowest: compound 1; then compound 2; then compound 3.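

In this assay the amide side chain proves sensitive to exchange: 4-(1-methylpiperidin-4-yl)-1H-pyrazol-1-yl in place of 4-((dimethylamino)methyl)-3-methyl-1H-pyrazol-1-yl gives a 5.6-fold higher number from compound 1 to compound 3 (0.74 log units; beyond the scatter) with the shared core and the amide linkage unchanged. The step is beyond the scatter even though both groups keep one five-membered aromatic ring and the same donor and acceptor counts, so those counts alone do not settle the value at this place. Nothing available here gives a reason for this step.

On these data alone, the exchange alters several features at once, so the part of the group that carries the step remains open. A pyrazole with a dimethylaminomethyl group and no methyl, or with a morpholine ring, would help separate these features.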